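This account rests on a few compounds, and the source may have more. Where it says the series, first, only, none or still open, it means among the compounds named here.

Measured in a functional assay on MCF7 cells (Homo sapiens) for inhibition, read by sulforhodamine B assay, with a stated time of 48 h; on this read-out lower numbers stand for stronger inhibition of growth and higher numbers for weaker inhibition of growth:
compound 1, `COc1cc(-c2cc(/C=C/C(=O)c3ccc(N)cc3)[nH]n2)cc(OC)c1OC`, gives 1500 nM;
compound 2, `COc1ccc(C(=O)/C=C/c2cc(-c3cc(OC)c(OC)c(OC)c3)n[nH]2)cc1OC`, gives 820 nM;
compound 3, `COc1ccc(C(=O)/C=C/c2cc(-c3cc(OC)c(OC)c(OC)c3)n[nH]2)cc1`, gives 1150 nM.

Compound 4, `COc1ccc(-c2cc(/C=C/C(=O)c3ccc(N)cc3)[nH]n2)cc1OC`, is not yet measured in this assay. Compound 1 and compound 4 differ by hydrogen in place of methoxy on an aromatic carbon. The same kind of change is known between compound 2 and compound 3, (hydrogen in place of methoxy on an aromatic carbon), where the step in this assay was a 1.4-fold higher number from compound 2 to compound 3 (0.15 log units; within the scatter). The two cores differ by 4-aminophenyl in place of 3,4-dimethoxyphenyl on a carbonyl carbon. The surroundings of the place are not identical: in compound 1 the place is also meta to a methoxy group (2 heavy atoms), which the place in compound 2 is not, so the change is the same kind of change, not the same.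

For this assay the expected step is a 1.4-fold higher number from compound 1 to compound 4 (0.15 log units; within the scatter). This rests on compound 1 at 1500 nM and on the step of a 1.4-fold higher number from compound 2 to compound 3 (0.15 log units; within the scatter). Compound 4 is accordingly estimated at 2100 nM, expected to fall between 1000 nM and 4500 nM.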

Compound 4, concentration for 50% growth inhibition: 2280 nM
Compound 4: the middle estimate sits 1.1-fold (0.04 log units) below what was measured, and the stated range covers the measured number.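

In this assay, hydrogen in place of methoxy on the core of compound 1 gives a 1.5-fold higher number from compound 1 to compound 4 (0.18 log units; within the scatter). Set beside the earlier case, the change carries from one core to the other with no detectable difference: the same change on two cores in this assay, a 1.4-fold higher number (0.15 log units; within the scatter) from compound 2 to compound 3 and a 1.5-fold higher number (0.18 log units; within the scatter) from compound 1 to compound 4, 1.1-fold (0.03 log units) apart, within the scatter of two such steps Both steps are small and lie within the scatter, so this shows only that the two cores agree, not that this methoxy matters for growth inhibition, and it says nothing about cores beyond these two.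

The compounds shown leave open whether another group at this place, such as hydroxyl, ethoxy or fluorine, would give a step beyond the scatter. Also open, on these data alone, is whether removing either remaining methoxy group would behave the same way.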